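Chloro to Fluoro on Compound 3: A Small Step Expected

A few compounds are considered here, and "the series" means these few. Any claim that something is new, unique, unknown or untested is made for them only; others in the source may bear on it.

Compound 1 `O=C(NCc1cc(C(F)(F)F)nn1-c1cccc(Cl)c1)Nc1cccc2[nH]c(=O)ccc12`, compound 2 `O=C(NCc1cc(C(F)(F)F)nn1-c1cccc(F)c1)Nc1cccc2[nH]c(=O)ccc12` and compound 3 `CC(C)(C)c1cc(CNC(=O)Nc2cccc3[nH]c(=O)ccc23)n(-c2cccc(Cl)c2)n1` share one core and were tested in an assay on HEK cells for antagonist activity at transient receptor potential cation channel subfamily V member 1 (Homo sapiens), read by FLIPR; on this read-out higher numbers stand for weaker inhibition and lower numbers for stronger inhibition. Compound 1 gives 1.71 nM, compound 2 gives 1.28 nM and compound 3 gives 4.41 nM, the highest number of the three. Compound 4 `CC(C)(C)c1cc(CNC(=O)Nc2cccc3[nH]c(=O)ccc23)n(-c2cccc(F)c2)n1` differs from compound 3 by fluoro in place of chloro on an aromatic carbon. Among the measured compounds shown here, the only measured step of this kind, a 1.3-fold lower number from compound 1 to compound 2 (0.13 log units; within the scatter), lies within the scatter, so that change on the phenyl ring made no real difference there. The same change applied to compound 3, which carries tert-butyl rather than trifluoromethyl, is therefore expected to produce no step beyond the scatter, a 1.3-fold lower number from compound 3 to compound 4 (0.10 log units; within the scatter). Compound 4 is estimated at 3.5 nM, with a range from 1.5 nM to 8 nM.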

Compound 4, half-maximal inhibitory concentration: 6.17 nM
Estimate against measurement, compound 4: 1.8-fold (0.25 log units) below, within the range that was stated.
By their numbers in this assay, from the lowest: compounds 2 and 1 (each within the scatter of the next); then compounds 3 and 4 (each within the scatter of the next).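

In this assay, fluoro in place of chloro at this ring position again makes no real difference, now with tert-butyl on the core (a 1.4-fold higher number from compound 3 to compound 4 (0.15 log units; within the scatter)), so the result holds on two cores: the same change on two cores in this assay, a 1.3-fold lower number (0.13 log units; within the scatter) from compound 1 to compound 2 and a 1.4-fold higher number (0.15 log units; within the scatter) from compound 3 to compound 4, 1.9-fold (0.27 log units) apart, within the scatter of two such steps. Tert-butyl in place of trifluoromethyl gives a real step with fluoro on the ring as well (a 4.8-fold higher number from compound 2 to compound 4 (0.68 log units; beyond the scatter)), and its size is in line with the step seen with chloro: the same change on two cores in this assay, a 2.6-fold higher number (0.41 log units; beyond the scatter) from compound 1 to compound 3 and a 4.8-fold higher number (0.68 log units; beyond the scatter) from compound 2 to compound 4, 1.9-fold (0.27 log units) apart, within the scatter of two such steps. Across these four compounds, the two changes therefore appear to act independently.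

On these data alone, only chloro and fluoro appear at this position, so what a methoxy group or an amine would do there remains open. As far as these compounds go, it is also open whether the independence would hold with a cyclopropyl group in place of tert-butyl.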